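A few compounds are considered here, and "the series" means these few. Any claim that something is new, unique, unknown or untested is made for them only; others in the source may bear on it.

Compound 3 `Cc1nc(S(C)(=O)=O)ccc1Oc1ncnc(OC2CCN(C(=O)SC(C)C)CC2)c1F` gives 81% in a functional assay on isolated protein for inhibition of Glucose-dependent insulinotropic receptor (Rattus norvegicus), read by HTRF and cAMP accumulation (on this read-out higher numbers stand for larger maximal responses and lower numbers for smaller maximal responses), the second highest of the three numbers shown. Compound 2 `Cc1nc(S(C)(=O)=O)ccc1Oc1ncnc(OC2CCN(C(=O)O[C@H](C)C(F)(F)F)CC2)c1F` gives 85%, and compound 1 `Cc1nc(S(C)(=O)=O)ccc1Oc1ncnc(OC2CCN(C(=O)OC(C)F)CC2)c1F` gives 68%; the step of a number 4 percentage points lower from compound 2 to compound 3 (within the scatter) is within the scatter, whereas a number 13 percentage points higher from compound 1 to compound 3 (beyond the scatter) and a number 17 percentage points higher from compound 1 to compound 2 (beyond the scatter) lie beyond it. Compound 4 `Cc1nc(S(C)(=O)=O)ccc1Oc1ncnc(OC2CCN(C(=O)c3noc(C(C)C)n3)CC2)c1F` differs from compound 3 by 5-isopropyl-1,2,4-oxadiazol-3-yl in place of isopropylsulfanyl on a carbonyl carbon. All measured steps swap one group on the same carbonyl carbon, and none was larger than modest; yet none of them brought in a five-membered aromatic ring, so they offer only loose guidance. A step near the scatter, in either direction, is therefore expected, a number 3 percentage points lower from compound 3 to compound 4 (within the scatter). Compound 4 is estimated at 78%, between 60% and 95%.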

Compound 4, largest response reached (reported as efficacy), in percent of the reference or control that the assay uses: 81%
Compound 4: middle estimate off by 3 percentage points, on the low side; measured number inside the range.
By their numbers in this assay, from the lowest: compound 1; then compounds 3, 4 and 2 (each within the scatter of the next).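

In this assay, a five-membered aromatic ring can stand on the carbonyl carbon without leaving the range of the two best open-chain groups: no change at the digits printed from compound 3 to compound 4 (within the scatter) and a number 4 percentage points lower from compound 2 to compound 4 (within the scatter). The 1-fluoroethyl carbamate remains the only outlier among the four, with a number 13 percentage points higher from compound 1 to compound 4 (beyond the scatter). Nothing shown accounts for this result.

On these data alone, it remains open whether the level would hold with a methyl or tert-butyl group in place of isopropyl on the oxadiazole, or with another ring, such as a pyridine, on the carbonyl carbon.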